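Swapping thiophene for 4-chlorophenyl: a lipophilicity estimate

A few compounds are considered here, and "the series" means these few. Any claim that something is new, unique, unknown or untested is made for them only; others in the source may bear on it.

Compound 1 `CC1=C(C(=O)OCc2cccnc2)C(c2cccc(O)c2)C2=C(CCCC2=O)N1`: 1.21
Compound 2 `CC1=C(C(=O)OCc2cccnc2)C(c2cccs2)C2=C(CCCC2=O)N1`: 1.4

Both numbers come from a physicochemical assay for lipophilicity, measured as octanol-water partition; a lower number here means a more polar compound, a higher number a more lipophilic compound. Compound 2 stands at 1.4 and compound 1 at 1.21, so the two cannot be told apart within the scatter of the measurement.

Compound 3 `CC1=C(C(=O)OCc2cccnc2)C(c2ccc(Cl)cc2)C2=C(CCCC2=O)N1` has not been measured yet. It keeps the core of compound 2 and differs at one place: 4-chlorophenyl in place of thiophen-2-yl on a saturated ring carbon.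

Going by the values given here, only one measured step bears on this change: a number 0.19 log units higher from compound 1 to compound 2 (within the scatter). It involves the same saturated ring carbon, but a different pair of groups, so it offers only a loose guide. Among the compounds with values here, neither measured compound carries chlorine, and no measured step shows what 4-chlorophenyl does here. The expectation in this assay is therefore a rise larger than the scatter, held with caution. The expected step is a number 0.60 log units higher from compound 2 to compound 3 (beyond the scatter). Compound 3 is estimated at 2, with an expected range from 1.5 to 2.5.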

Compound 3, partition coefficient: 1.87
Compound 3: middle estimate off by 0.13 log units, on the high side; the range from low to high includes it.
By their numbers in this assay, from the lowest: compounds 1 and 2 (each within the scatter of the next); then compound 3.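

In this assay, the choice of group on this saturated ring carbon now produces a difference that can be read: 4-chlorophenyl in place of thiophen-2-yl gives a number 0.47 log units higher from compound 2 to compound 3 (beyond the scatter). The comparison with the 3-hydroxyphenyl group points the same way, with a number 0.66 log units higher from compound 1 to compound 3 (beyond the scatter), so compound 3 stands clearly apart from both earlier compounds, while compound 1 and compound 2 remain within the scatter of each other. The change replaces a five-membered aromatic ring holding sulfur with a six-membered carbon ring bearing chlorine, so these compounds cannot separate the contribution of the ring from that of the chlorine, and no measurement at hand accounts for the step.

The compounds shown leave open where a plain phenyl group would fall relative to compound 2 and compound 3, a comparison that would divide this step between the ring and the chlorine. They also leave open what an amine or a carboxylic acid on the same saturated ring carbon would do to the number, and whether 4-chlorophenyl would give a step of similar size on another core.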